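A Benzyl Substituent Swap Beneath the Cytotoxicity Ceiling

A few compounds are considered here, and "the series" means these few. Any claim that something is new, unique, unknown or untested is made for them only; others in the source may bear on it.

Compound 3 `CCOC(=O)c1cnc(N2CCN(Cc3cccc([N+](=O)[O-])c3)CC2)nc1Oc1c(C)cc(-c2ccc(C#N)cc2)cc1C` has been assessed in an ADME assay on MT4 cells (Homo sapiens) for cytotoxicity, read by MTT assay, with a stated time of 4 days; a higher number here means that more compound is tolerated, a lower number that less compound is tolerated. In this assay compound 3 gives > 125000 nM, which is a limit of the assay and not a number. Two relatives of it are known, compound 1 `CCOC(=O)c1cnc(N2CCN(Cc3ccccc3C#N)CC2)nc1Oc1c(C)cc(-c2ccc(C#N)cc2)cc1C` and compound 2 `CCOC(=O)c1cnc(N2CCN(Cc3ccccc3F)CC2)nc1Oc1c(C)cc(-c2ccc(C#N)cc2)cc1C`. In this assay compound 1 gives > 125000 nM, a limit. In this assay compound 2 gives > 125000 nM, again a limit. The steps a step that the two limits leave unreadable from compound 1 to compound 2, a step that the two limits leave unreadable from compound 1 to compound 3 and a step that the two limits leave unreadable from compound 2 to compound 3 therefore cannot be read in size, since (the limit of > 125000 nM in this assay, at which 3 of the 3 values shown sit).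

Compound 4 `CCOC(=O)c1cnc(N2CCN(Cc3cccc(OC)c3)CC2)nc1Oc1c(C)cc(-c2ccc(C#N)cc2)cc1C` differs from compound 3 by methoxy in place of nitro on an aromatic carbon. Going by the values given here, no measured step bears on this change with a readable size or direction; varying the benzyl substituent across compounds 1, 2 and 3 has left every value at the ceiling. Compound 4 is therefore expected to sit at that same limit in this assay, with an estimate of 125000 nM and a range from 60000 nM to 250000 nM. The step of a number no higher from compound 3 to compound 4 (the limit leaves the size open) is expected to be none beyond the scatter.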

Compound 4, half-maximal cytotoxic concentration: > 125000 nM
Compound 4: a limit, no number; the forecaster's own chance of this, stated with the estimate: 85%; the middle value lies on the limit itself.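

Compound 4 also returns only a limit in this assay, so its steps from compound 1, compound 2 and compound 3 cannot be read in size: the limit of > 125000 nM in this assay, at which 4 of the 4 values shown sit.

The compounds shown leave open whether any benzyl substituent changes how much compound is tolerated, and by how much.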